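Chloro in place of fluoro, from compound 3

The source may hold more compounds than are shown below. What is called first, only, known or untested is meant among the compounds shown, and "the series" means these compounds.

Of the compounds shown here, three sharing one core have been measured in a functional assay on HeLa cells (Homo sapiens) for inhibition, read by CCK-8 assay, with a stated time of 72 h, tested at 2 uM; on this read-out higher numbers stand for more inhibition of growth at the one concentration tested and lower numbers for less inhibition of growth. Compound 1 (`Cc1ccc(SCc2ccc(C(=O)Nc3ccccc3N)cc2)cc1`) gives 33.8%, compound 2 (`Nc1ccccc1NC(=O)c1ccc(CSCCc2ccccc2)cc1`) gives 27.7% and compound 3 (`Nc1ccccc1NC(=O)c1ccc(CSc2ccc(F)cc2)cc1`) gives 27.9%. Compound 3 thus stands within the scatter of both other compounds, and no order can be read among the three.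

The next structure is compound 4 (`Nc1ccccc1NC(=O)c1ccc(CSc2ccc(Cl)cc2)cc1`). The change is chloro in place of fluoro on an aromatic carbon, para to a large group. Among the measured compounds shown here, no measured step exchanges these two groups. The closest is a number 5.9 percentage points lower from compound 1 to compound 3 (within the scatter), with fluoro in place of methyl on an aromatic carbon, and it lies within the scatter. The larger changes on the sulfur, a number 6.1 percentage points lower from compound 1 to compound 2 (within the scatter) and a number 0.2 percentage points higher from compound 2 to compound 3 (within the scatter), also stay within it. No step beyond the scatter is therefore expected in this assay, and no direction is firmly supported.

The expected step, a number 2.1 percentage points higher from compound 3 to compound 4 (within the scatter), is small. For compound 4 the estimated value is 30%, with an expected range from 21% to 40%.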

Compound 4, percent growth inhibition at one concentration: 19.2%
Beside the measured number, compound 4's estimate is 10.8 percentage points above it, outside the stated range (below it).
By their numbers in this assay, from the lowest: compounds 4, 2, 3 and 1 (each within the scatter of the next, the first and the last beyond it).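

In this assay the exchange of fluoro for chloro on the aromatic carbon para to a large group stays within the scatter (a number 8.7 percentage points lower from compound 3 to compound 4 (within the scatter)), as does 4-chlorophenyl in place of phenethyl on the sulfur (a number 8.5 percentage points lower from compound 2 to compound 4 (within the scatter)). Among the compounds shown here, the first step beyond the scatter arises at this same aromatic carbon, with chloro in place of methyl (a number 14.6 percentage points lower from compound 1 to compound 4 (beyond the scatter)), so the group here can matter in this assay, although that rests on one modest step. Nothing available accounts for this step.

From the compounds shown here alone, whether an amine, a carboxylic acid or a methoxy group on this aromatic carbon would separate from methyl and chloro remains open. Also open, going by these compounds, is whether a longer chain on the sulfur would give a step beyond the scatter.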